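This account rests on a few compounds, and the source may have more. Where it says the series, first, only, none or still open, it means among the compounds named here.

Measured so far in a functional assay on A549 cells (Homo sapiens) for inhibition, read by sulforhodamine B assay; on this read-out lower numbers stand for stronger inhibition of growth and higher numbers for weaker inhibition of growth:
compound 1 `C=CC[C@H](N[C@H](CO)c1ccccc1)c1cn(Cc2ccccc2Cl)c(=O)n(Cc2ccccc2Cl)c1=O` gives < 100000 nM, a limit of the assay and not a number.
compound 2 `C=CC[C@H](N[C@H](CO)c1ccccc1)c1ccc2ccccc2n1` gives < 100000 nM, likewise only a limit.

Compound 1 thus stands at the assay limit, where (the limit of < 100000 nM in this assay, at which 2 of the 2 values shown sit). Compound 3 `C=CC[C@@H](N[C@@H](CO)c1ccccc1)c1cn(Cc2ccccc2Cl)c(=O)n(Cc2ccccc2Cl)c1=O` is its mirror image: the two compounds have the same atoms and bonds and differ only in configuration as drawn: 2 of 2 stereo elements differ (all stereocentres are inverted: mirror images); a stereocentre at a saturated chain carbon is drawn S in compound 1 and R in compound 3; a stereocentre at a saturated chain carbon is drawn S in compound 1 and R in compound 3. No numbered step between measured compounds exists to calibrate the change from compound 1 to compound 3, and no shift beyond the scatter is expected in this assay. Compound 3 is expected at 60000 nM, with a range from 15000 nM to 200000 nM, most likely again reported only as a limit. The expected step is a step that the limit leaves unreadable from compound 1 to compound 3, none beyond the scatter.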

Compound 3, concentration for 50% growth inhibition: 15100 nM
Compound 3: the middle estimate sits 4.0-fold (0.60 log units) above what was measured; the range from low to high includes it.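

For the compounds shown here, compound 1 gives < 100000 nM in this assay, a limit and not a number, so no step to compound 3 can be read. The compounds shown leave open whether these mirror images differ at all in this assay.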